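Chloro added to the phenyl of compound 2

The compounds below may be only part of what the source reports. "The series", "measured", "known", "first", "only" and "open" are said of these compounds alone.

Of the compounds shown here, three with a shared core have been measured. In a functional assay on OVCAR-3 cells (Homo sapiens) for antiproliferative activity, read by sulforhodamine B assay, with a stated time of 72 h (a lower number here means a stronger inhibitor, a higher number a weaker inhibitor), compound 1 `CCN1C(=O)CS/C1=N/Nc1nncc2ccccc12` gives 55 nM, compound 2 `C(=C/c1ccccc1)\C(=N\Nc1nncc2ccccc12)c1ccccc1` gives 3.3 nM and compound 3 `S=C(NNc1nncc2ccccc12)Nc1ccccc1` gives 6 nM. Compound 2 stands with compound 3 at the low end of these numbers, the two within the scatter of each other, while compound 1 lies beyond the scatter from compound 2. Compound 4 `Clc1ccc(C(/C=C/c2ccccc2)=N\Nc2nncc3ccccc23)cc1` has chloro in place of hydrogen on an aromatic carbon of compound 2, para to a large group: chloro in place of hydrogen on an aromatic carbon. Going by the values given here, no measured pair shows this change in this assay, so no step beyond the scatter is expected in either direction. The estimated step, a 1.1-fold higher number from compound 2 to compound 4 (0.03 log units; within the scatter), is small. The expected value for compound 4 is 3.5 nM, with an estimated range of 1 nM to 12 nM.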

Compound 4, half-maximal inhibitory concentration: 5.4 nM
Estimate against measurement, compound 4: 1.5-fold (0.19 log units) below; the range from low to high includes it.
By their numbers in this assay, from the lowest: compounds 2, 4 and 3 (each within the scatter of the next); then compound 1.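

In this assay, going by these compounds alone, the exchange of phenyl for 4-chlorophenyl gives a 1.6-fold higher number from compound 2 to compound 4 (0.21 log units; within the scatter) and is the first step between compounds that differ in one place. This position, para to a large group, therefore accepts chloro in place of hydrogen with the two values remaining within the scatter. Nothing available explains this result.

Still open, on these data alone, is whether a methoxy, an amine or a carboxylic acid at this position would also remain within the scatter of compound 2. Chloro on the other phenyl of compound 2 is equally unresolved.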